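A few compounds are considered here, and "the series" means these few. Any claim that something is new, unique, unknown or untested is made for them only; others in the source may bear on it.

Working notes on the series in an ADME assay on HaCaT cells (Homo sapiens) for antiproliferative activity, read by MTT assay, with a stated time of 48 h; on this read-out lower numbers stand for stronger inhibition and higher numbers for weaker inhibition.

Compound 3 `COc1ccc(N/C=C\C(=O)c2cn(-c3ccccc3)nc2-c2ccc(OC)cc2)cc1` stands at the limit of this assay: in this assay compound 3 gives > 50000 nM, which is a limit and not a number. Compound 2 `COc1ccc(-c2nn(-c3ccccc3)cc2C(=O)/C=C\Nc2ccc(C(F)(F)F)cc2)cc1` sits at the same limit, with compound 2 giving > 50000 nM in this assay. The step from compound 2 to compound 3 a step that the two limits leave unreadable from compound 2 to compound 3 is therefore not readable, because both values sit at the limit of > 50000 nM in this assay, at which 2 of the 3 values shown sit. Going by the values given here, compound 1 `COc1cc(N/C=C\C(=O)c2cn(-c3ccccc3)nc2-c2ccc(Cl)cc2)cc(OC)c1OC` is the only member of the set with a number: in this assay compound 1 gives 46600 nM.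

Compound 4 `COc1ccc(-c2nn(-c3ccccc3)cc2C(=O)/C=C\Nc2cc(OC)c(OC)c(OC)c2)cc1` has not yet been measured in this assay. It differs from compound 3 by 3,4,5-trimethoxyphenyl in place of 4-methoxyphenyl on an amine nitrogen. Among the compounds with values here, no measured step in this assay bears directly on that change; the one readable comparison, between compound 2 and compound 3, is blind at both ends. Compound 1, which carries the same 3,4,5-trimethoxyphenyl on the amine nitrogen as compound 4, shows a value within the scatter of the limit. The expectation for compound 4 is thus a value at or near the limit, with the step from compound 3 to compound 4 estimated as a number no higher from compound 3 to compound 4 (the limit leaves the size open), no change beyond the scatter. Compound 4 is estimated at 50000 nM, between 25000 nM and 100000 nM.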

Compound 4, half-maximal inhibitory concentration: > 50000 nM
Compound 4 ended at the assay's limit (the forecaster's own chance of this, stated with the estimate: 60%); the middle value lies on the limit itself.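

With 3,4,5-trimethoxyphenyl in place of 4-methoxyphenyl on the amine nitrogen, compound 4 gives > 50000 nM in this assay, which is a limit and not a number, so this larger group does not bring the methoxy-bearing compounds onto a readable value. Going by these compounds alone, the only step that can be read is an at least 1.0-fold higher number from compound 1 to compound 4 (0.03 log units; that floor lies within the scatter), for methoxy in place of chloro on an aromatic carbon; it gives a floor and not a size, and with that floor inside the scatter, the chloro of compound 1 cannot be said to matter in the presence of 3,4,5-trimethoxyphenyl. The steps from compound 2 and from compound 3 to compound 4 cannot be read, and the series now rests largely on one limit: the limit of > 50000 nM in this assay, at which 3 of the 4 values shown sit.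

As far as these compounds go, how far compound 2, compound 3 and compound 4 lie past that limit stays open, so no ranking among the three amine nitrogen substituents can be given. The compounds shown also say nothing about a hydroxy or dimethylamino group on that aromatic ring, or about a bromo or fluoro group in place of the chloro of compound 1.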